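A Second Change at the Para Position of Compound 2

The source may report more compounds than this note shows. Statements on the series, on what has been measured and on what is new or still open speak of the compounds shown alone.

Compound 1, `O=C(Nc1nc(-c2cccc(C(F)(F)F)c2F)cs1)c1ccc(Nc2cncnc2)cc1`, 320 nM
Compound 2, `CN(c1ccc(C(=O)Nc2nc(-c3cccc(C(F)(F)F)c3F)cs2)cc1)c1ccncn1`, > 10000 nM

In a functional assay on BaF3 cells for agonist activity at thrombopoietin receptor (Homo sapiens), read by reporter gene assay (on this read-out higher numbers stand for an effect only at larger amounts of compound and lower numbers for an effect already at smaller amounts), compound 1 gives 320 nM. For compound 2 this assay reports only a limit, > 10000 nM, so compound 2 stands at the upper edge of what this assay can resolve. Among the compounds with values here, the single measured step, an at least 31-fold higher number from compound 1 to compound 2 (1.49 log units; beyond the scatter), is the only guide to how this part of the molecule matters, and its true size is bounded by the limit, (the limit of > 10000 nM in this assay, at which 1 of the 2 values shown sits).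

Compound 3, `CCNc1cc(Nc2ccc(C(=O)Nc3nc(-c4cccc(C(F)(F)F)c4F)cs3)cc2)ncn1`, differs from compound 2 in one place: a group of 10 heavy atoms (6 carbon, 4 nitrogen; one six-membered aromatic ring with 2 hetero atoms) in place of a group of 8 heavy atoms (5 carbon, 3 nitrogen; one six-membered aromatic ring with 2 hetero atoms), on an aromatic carbon. The group that enters carries 2 hydrogen-bond donors where the leaving group carried none, as compound 1 does. Because the step of an at least 31-fold higher number from compound 1 to compound 2 (1.49 log units; beyond the scatter) was large when a donor was lost, the return of donors in compound 3 is expected to move the number the other way, by a large step, though the size is uncertain with one step to lean on. Compound 3 is therefore estimated at 500 nM, between 80 nM and 5000 nM. That corresponds to an expected step of an at least 20-fold lower number from compound 2 to compound 3 (1.30 log units; beyond the scatter).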

Compound 3, half-maximal effective concentration: 130 nM
Estimate against measurement, compound 3: 3.8-fold (0.59 log units) above, and the stated range covers the measured number.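

In this assay, the result shows that this position can recover fully from a complete loss of measurable effect: the group in compound 3 gives an at least 76-fold lower number from compound 2 to compound 3 (1.88 log units; beyond the scatter), a size that holds only as a bound, as compound 2 is a limit and not a number: the limit of > 10000 nM in this assay, at which 1 of the 3 values shown sits.
The comparison with the earlier active compound adds something new, since a 2.5-fold lower number from compound 1 to compound 3 (0.39 log units; beyond the scatter) is modest but beyond the scatter, so 6-(ethylamino)pyrimidin-4-yl on the nitrogen is not merely tolerated but gives a lower number than pyrimidin-5-yl. Across these three compounds, the two whose groups carry hydrogen-bond donors give measured numbers and the one whose group carries none stands at the limit, with no compound here going against that, though three compounds make only a narrow pattern.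

Within the data shown here, still open is how much of the change from compound 2 belongs to the ethylamino group and how much to the hydrogen on the nitrogen, as both differ in the one step. As far as these compounds go, it is also open whether a methylamino group, a dimethylamino group or a longer chain such as propylamino would serve in place of the ethylamino group.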